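Swapping pyridin-4-yl for furan-2-yl on a shared core

The source may hold more compounds than are shown below. What is called first, only, known or untested is meant among the compounds shown, and "the series" means these compounds.

Values in a functional assay on MCF7 cells (Homo sapiens) for inhibition, read by MTT assay, with a stated time of 48 h; a lower number here means a stronger inhibitor, a higher number a weaker inhibitor:
- compound 1 `CCOC(=O)c1c(N)sc(/N=C/c2ccc([N+](=O)[O-])o2)c1C(=O)OCC`: 2400 nM
- compound 2 `CCOC(=O)c1c(N)sc(/N=C/c2ccc(Br)cc2)c1C(=O)OCC`: 12500 nM
- compound 3 `CCOC(=O)c1c(N)sc(/N=C/c2ccncc2)c1C(=O)OCC`: 92200 nM

Of these three, compound 3 gives the highest number, 92200 nM, which makes it the weakest inhibitor measured so far. The next structure, compound 4 `CCOC(=O)c1c(N)sc(/N=C/c2ccco2)c1C(=O)OCC`, keeps the shared core and changes one group: furan-2-yl in place of pyridin-4-yl on a carbon with a double bond to nitrogen. This puts furan-2-yl in place of pyridin-4-yl on a carbon with a double bond to nitrogen.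

Two measured steps end at pyridin-4-yl: a 38-fold higher number from compound 1 to compound 3 (1.58 log units; beyond the scatter), and a 7.4-fold higher number from compound 2 to compound 3 (0.87 log units; beyond the scatter). The first is large and the second modest. A third step, a 5.2-fold higher number from compound 1 to compound 2 (0.72 log units; beyond the scatter), shows that the other two groups also differ from each other. For the measured compounds named here, no measured compound carries furan-2-yl without the nitro group. The closest relative is compound 1, at 2400 nM, but it need not predict the outcome. A modest fall in the number in this assay is therefore expected. The expected step is a 4.6-fold lower number from compound 3 to compound 4 (0.66 log units; beyond the scatter). Compound 4 is estimated at 20000 nM, with an expected range of 6000 nM to 65000 nM.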

Compound 4, half-maximal inhibitory concentration: 62200 nM
Compound 4: the middle estimate sits 3.1-fold (0.49 log units) below what was measured, and the stated range covers the measured number.
By their numbers in this assay, from the lowest: compound 1; then compound 2; then compounds 4 and 3 (each within the scatter of the next).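

In this assay, furan-2-yl and pyridin-4-yl on this carbon cannot be told apart: the change gives a 1.5-fold lower number from compound 3 to compound 4 (0.17 log units; within the scatter) despite the different ring sizes. The nitro group matters far more, since hydrogen in place of nitro on an aromatic carbon gives a 26-fold higher number from compound 1 to compound 4 (1.41 log units; beyond the scatter), so the furan ring alone does not carry the activity of compound 1, and furan-2-yl in place of 4-bromophenyl gives a 5.0-fold higher number from compound 2 to compound 4 (0.70 log units; beyond the scatter). Nothing available here explains these differences.

Going by these compounds, it remains open whether a nitrile or a methyl group in place of nitro on the furan ring would keep any of the effect of nitro. On these data alone, it is also open whether adding nitro to the pyridin-4-yl ring of compound 3 would give a similar step.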